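The compounds below may be only part of what the source reports. "The series", "measured", "known", "first", "only" and "open" are said of these compounds alone.

Measured compounds:
compound 1, `Cc1cc(NC(=O)Nc2ccc([N+](=O)[O-])c(C(F)(F)F)c2)c2ccccc2n1` — > 25000 nM
compound 2, `COc1ccc(NC(=O)Nc2cc(C)nc3ccccc23)cc1` — > 25000 nM
compound 3, `Cc1cc(NC(=O)Nc2cccc(C(N)=O)c2)c2ccccc2n1` — > 25000 nM

In an ADME assay on HepG2 cells (Homo sapiens) for cytotoxicity, with a stated time of 72 h (on this read-out lower numbers stand for an effect already at smaller amounts and higher numbers for an effect only at larger amounts of compound), none of the three measured compounds gives a number. Compound 1 reaches only a limit of the assay. Compound 2 likewise reaches only a limit. Compound 3 also reaches only a limit. Compound 2 therefore stands where every shown value stands, namely at the limit of > 25000 nM in this assay, at which 3 of the 3 values shown sit, and nothing separates it from compound 1 or compound 3 on the read-out.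

The step from compound 2 to compound 4 changes one place on the shared core: fluoro in place of methoxy on an aromatic carbon. Compound 4, `Cc1cc(NC(=O)Nc2ccc(F)cc2)c2ccccc2n1`, has not yet been measured in this assay. For the measured compounds named here, no measured step between two compounds exists, so the size of the change cannot be read off from a neighbouring pair. Given that compound 2 sits at the limit, the step that the limit leaves unreadable from compound 2 to compound 4 is expected to be none beyond the scatter. Compound 4 is accordingly estimated to come out at 30000 nM, with a range from 15000 nM to 60000 nM, most likely again reported as a limit rather than a number.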

Compound 4, half-maximal effective concentration: > 25000 nM
Compound 4: no number, only a limit; the forecaster's own chance of this, stated with the estimate: 85%; the middle value lies beyond the limit too.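

The step from compound 2 to compound 4, fluoro in place of methoxy on an aromatic carbon, cannot be read, since both compounds reach only a limit: the limit of > 25000 nM in this assay, at which 4 of the 4 values shown sit. The compounds shown leave open at what concentration, if any, each would affect these cells.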